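Halogen substitution on the phenyl of the oxime series

The source may hold more compounds than are shown below. What is called first, only, known or untested is meant among the compounds shown, and "the series" means these compounds.

Compound 1 `O/N=C(\CCN1CCN(c2ccccn2)CC1)c1ccccc1` is the shared core with an unsubstituted phenyl on the carbon with a double bond to nitrogen. Going by the values given here, in a functional assay on HEK293 cells with D(4) dopamine receptor (Homo sapiens) as the target, read by FLIPR (a higher number here means that more compound is needed for the effect, a lower number that less compound is needed), compound 1 gives 4.4 nM, the lowest of the three numbers measured so far. Compound 2 `O/N=C(\CCN1CCN(c2ccccn2)CC1)c1ccccc1Cl` gives 24 nM in this assay, a step of a 5.5-fold higher number from compound 1 to compound 2 (0.74 log units; beyond the scatter). Compound 3 `O/N=C(\CCN1CCN(c2ccccn2)CC1)c1ccc(Cl)cc1` gives 475 nM, a step of a 110-fold higher number from compound 1 to compound 3 (2.03 log units; beyond the scatter); between the two chloro compounds the step is a 20-fold higher number from compound 2 to compound 3 (1.30 log units; beyond the scatter).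

Compound 4 `O/N=C(\CCN1CCN(c2ccccn2)CC1)c1cc(F)cc(F)c1` differs from compound 1 by 3,5-difluorophenyl in place of phenyl on a carbon with a double bond to nitrogen. Among the compounds with values here, no fluoro compound has been measured, so the only bearing steps are the two chloro substitutions, both of which raised the number beyond the scatter, modestly in one case and strongly in the other. Two fluorines on the phenyl are therefore expected to raise the number as well, by an amount between those two steps. For compound 4 the estimated step is a 10-fold higher number from compound 1 to compound 4 (1.01 log units; beyond the scatter). Compound 4 is estimated at 45 nM, within 8 nM to 300 nM.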

Compound 4, half-maximal effective concentration: 19.4 nM
Estimate against measurement, compound 4: 2.3-fold (0.37 log units) above; the range from low to high includes it.
By their numbers in this assay, from the lowest: compound 1; then compounds 4 and 2 (each within the scatter of the next); then compound 3.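

Fluoro substitution on this phenyl raises the number only to a limited degree in this assay: 3,5-difluorophenyl in place of phenyl gives a 4.4-fold higher number from compound 1 to compound 4 (0.64 log units; beyond the scatter) and leaves compound 1 with the lowest number of the four. Measured against 2-chlorophenyl, the same group gives a 1.2-fold lower number from compound 2 to compound 4 (0.09 log units; within the scatter) and so does not separate compound 2 from compound 4, whereas against 4-chlorophenyl it gives a 24-fold lower number from compound 3 to compound 4 (1.39 log units; beyond the scatter) and leaves compound 3 alone at the high end, so a large rise does not follow from every substitution on this phenyl. Nothing at hand explains these differences.

Still open, as far as these compounds go, is whether the large rise with 4-chlorophenyl belongs to chloro itself or would also appear with 4-fluorophenyl. Also open, from the compounds shown here alone, is how a methoxy or a nitrile on the same phenyl would compare with the halogens.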